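Lengthening the sulfur-bound chain of compound 1 by one carbon

This account rests on a few compounds, and the source may have more. Where it says the series, first, only, none or still open, it means among the compounds named here.

Compound 1, with the structure `CCSc1n[nH]c(-n2[se]c3ccccc3c2=O)n1`, carries an ethylsulfanyl group on its core. In a functional assay on SMMC-7721 cells (Homo sapiens) for antiproliferative activity, read by CCK-8 assay, with a stated time of 48 h (on this read-out lower numbers stand for stronger inhibition and higher numbers for weaker inhibition), compound 1 gives 10000 nM, the lowest number among the compounds with a measured value here. Compound 2, `Cc1ccc(CSc2n[nH]c(-n3[se]c4ccccc4c3=O)n2)cc1`, replaces the methyl at the end of that chain with a 4-methylphenyl group; for compound 2 the assay reports only a limit, > 50000 nM, and the limit of > 50000 nM in this assay, at which 1 of the 3 values shown sits, marks where that limit sits. Compound 3, `O=c1c2ccccc2[se]n1-c1nc(SCc2ccc(F)cc2)n[nH]1`, makes the matching change with a 4-fluorophenyl group and gives 46100 nM. The step of an at least 5.0-fold higher number from compound 1 to compound 2 (0.69 log units; beyond the scatter) and the step of a 4.6-fold higher number from compound 1 to compound 3 (0.66 log units; beyond the scatter) both show that adding an aromatic ring at this end of the chain weakens inhibition.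

Compound 4, `CCCSc1n[nH]c(-n2[se]c3ccccc3c2=O)n1`, is the unmeasured analogue: methyl in place of hydrogen on a saturated chain carbon, two bonds along the chain from a sulfur. This is a far smaller change than either measured step, adding a single carbon rather than a ring, so those steps do not set its size; they only hint that growth at this position does not help. The expected step of a 1.3-fold higher number from compound 1 to compound 4 (0.11 log units; within the scatter) is therefore small, within or barely beyond the scatter, and leaning weaker. Compound 4 is estimated at 13000 nM, within a range from 5000 nM to 35000 nM.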

Compound 4, half-maximal inhibitory concentration: 6020 nM
Estimate against measurement, compound 4: 2.2-fold (0.33 log units) above, within the range that was stated.
By their numbers in this assay, from the lowest: compounds 4 and 1 (each within the scatter of the next); then compound 3. At a limit, above all of these: compound 2.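

The added carbon makes no difference that can be told from the usual variation in this assay: the change from ethylsulfanyl to propylsulfanyl gives a 1.7-fold lower number from compound 1 to compound 4 (0.22 log units; within the scatter), so this position tolerates one more chain carbon, which the ring-bearing compounds could not show. The loss seen earlier therefore does not follow from any growth at the chain end, at least not for this small step, as the propyl compound keeps a clear margin over the 4-fluorophenyl compound, with a 7.7-fold lower number from compound 3 to compound 4 (0.88 log units; beyond the scatter). The margin over the 4-methylphenyl compound, an at least 8.3-fold lower number from compound 2 to compound 4 (0.91 log units; beyond the scatter), is only a minimum, since compound 2 has a limit and not a number: the limit of > 50000 nM in this assay, at which 1 of the 4 values shown sits.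

The compounds shown leave open how far this tolerance extends, for instance whether a longer chain such as butyl would hold this level or fall away toward the ring-bearing compounds. They also leave open whether an amine or a carboxylic acid at the end of the chain would move the number in either direction, since only plain alkyl chains and substituted phenyl groups appear here.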